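The compounds below may be only part of what the source reports. "The series", "measured", "known", "first", "only" and "open" are said of these compounds alone.

Working notes on the series. Compound 1 `Cc1cccc2c1CN(C(=O)c1cc(S(C)(=O)=O)ccc1O[C@@H](C)C(F)(F)F)C2` reads 73 ug/mL in a physicochemical assay for solubility (a lower number here means a less soluble compound, a higher number a more soluble compound), and compound 2 `C[C@H](Oc1ccc(S(C)(=O)=O)cc1C(=O)N1Cc2cnc(C(F)(F)F)cc2C1)C(F)(F)F` reads 470 ug/mL in the same measurement. Compound 3 `CC(C)Oc1ccc(S(C)(=O)=O)cc1C(=O)N1Cc2cc(C(F)(F)F)cnc2C1` reads 114 ug/mL there and sits within the scatter of compound 1, while compound 2 stands beyond the scatter on the higher side of compound 3.

Compound 4 `CS(=O)(=O)c1ccc(OCc2ccccc2)c(C(=O)N2Cc3cc(C(F)(F)F)cnc3C2)c1` differs from compound 3 in one place, with benzyl in place of isopropyl on an oxygen on an aromatic ring as the count of the change, benzyl in place of isopropyl on an oxygen on an aromatic ring. Among the measured compounds shown here, no two measured compounds differ in only one place, so the series offers no direct measure of this change and the expectation below carries a wide range.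

In this assay a downward move beyond the scatter is expected. The estimated size is a 2.9-fold lower number from compound 3 to compound 4 (0.45 log units; beyond the scatter) for this change. Compound 4 is estimated at 40 ug/mL with 12 ug/mL to 110 ug/mL as the expected range.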

Compound 4, solubility: 72 ug/mL
For compound 4 the middle estimate is 1.8-fold (0.26 log units) below the measured one; the range from low to high includes it.
By their numbers in this assay, from the lowest: compounds 4, 1 and 3 (each within the scatter of the next); then compound 2.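

Among the compounds shown here, this is the first step that isolates a single change: in this assay, benzyl in place of isopropyl on an oxygen on an aromatic ring gives a 1.6-fold lower number from compound 3 to compound 4 (0.20 log units; within the scatter) with no other difference in structure. The entering group brings 7 heavy atoms and one six-membered aromatic ring of carbon only where the leaving group had 3 heavy atoms and no ring, yet the step stays within the scatter, so this position accepts the larger group on this core without a measurable shift. Nothing available here bears on the reason for this result.

Going by these compounds, whether the same swap reads alike on the cores of compound 1 and compound 2 remains open. Also open, on these data alone, is how an amine, a carboxylic acid or a longer chain on this oxygen would read in this assay on the core of compound 3.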